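Lengthening the acid-bearing chain of compound 3

This account rests on a few compounds, and the source may have more. Where it says the series, first, only, none or still open, it means among the compounds named here.

The measured compounds:
Compound 1, `O=C(O)CCc1cc(-c2cccnc2)cc2c1CCC(NS(=O)(=O)c1ccc(Cl)cc1)C2`, in an assay on blood with Thromboxane-A synthase (Homo sapiens) as the target; a higher number here means a weaker inhibitor, a lower number a stronger inhibitor: > 5000 nM, which is a limit of the assay and not a number.
Compound 2, `O=C(O)CCc1cc(Cc2cccnc2)cc2c1CCC(NS(=O)(=O)c1ccc(Cl)cc1)C2`: 1100 nM.
Compound 3, `O=C(O)CC/C=C/c1c(Cc2cccnc2)ccc2c1CCC(NS(=O)(=O)c1ccc(Cl)cc1)C2`: 1400 nM.

Compound 3 holds the highest of the two numbers in this assay, and its nearest neighbour is compound 2, a difference that lies within the scatter. Compound 1 sits at a limit, and only that can be said of it; (the limit of > 5000 nM in this assay, at which 1 of the 3 values shown sits).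

Among the measured compounds shown here, the one measured step, an at least 4.5-fold lower number from compound 1 to compound 2 (0.65 log units; beyond the scatter), concerns the link to the pyridine and says nothing about the acid-bearing chain.

Compound 4, `O=C(O)CCC/C=C\c1c(Cc2cccnc2)ccc2c1CCC(NS(=O)(=O)c1ccc(Cl)cc1)C2`, differs from compound 3 in that chain only: 5-carboxypent-1-en-1-yl in place of 4-carboxybut-1-en-1-yl on an aromatic carbon. For the measured compounds named here, no measured step touches this part of the molecule, so there is no ground in these data for expecting a shift in either direction beyond the scatter. Compound 4 is therefore expected to come out close to compound 3, with the step of no change at the digits printed from compound 3 to compound 4 (within the scatter) estimated as no more than the usual scatter. The estimate for compound 4 in this assay is 1400 nM, with a range from 450 nM to 4500 nM.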

Compound 4, half-maximal inhibitory concentration: 350 nM
Compound 4: the middle estimate sits 4.0-fold (0.60 log units) above what was measured; measured number below the stated range.
By their numbers in this assay, from the lowest: compound 4; then compounds 2 and 3 (each within the scatter of the next). At a limit, above all of these: compound 1.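

The earlier compounds shown here said nothing about the acid-bearing chain, and this pair shows that the assay responds to a small change there: in this assay, replacing 4-carboxybut-1-en-1-yl with 5-carboxypent-1-en-1-yl gives a 4.0-fold lower number from compound 3 to compound 4 (0.60 log units; beyond the scatter), so compound 4 is the stronger inhibitor of the two. Among the compounds shown here, the change is not only one of length, as the structures also show a trans double bond in compound 3 and a cis double bond in compound 4, and this pair alone cannot separate those two differences. Nothing measured here accounts for the gain, as the only supporting observation concerns an assay limit and does not bear on this chain.

Going by these compounds, it remains open whether the gain follows the added length or the cis arrangement, which the trans form of 5-carboxypent-1-en-1-yl or the cis form of 4-carboxybut-1-en-1-yl could help to settle. Also open, on these data alone, are how a longer chain such as 6-carboxyhex-1-en-1-yl, a fully saturated chain, or a tetrazole in place of the carboxylic acid would fare at this position.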